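Notes on the step from compound 1 to compound 4

A few compounds are considered here, and "the series" means these few. Any claim that something is new, unique, unknown or untested is made for them only; others in the source may bear on it.

In a physicochemical assay for solubility, read by LC-MS, in phosphate buffer, with a stated time of 24 h, at pH 7.4 (a lower number here means a less soluble compound, a higher number a more soluble compound), compound 1 (`C[C@@H]1CC(=O)N(c2cnc(NCc3c(F)ccc4c3CCO4)n3cnnc23)C1`) gives 130000 nM and stands highest of the three measured numbers. Compound 2 (`Cc1ncccc1-c1cnc(NCc2c(F)ccc3c2CCO3)c2ncc(=O)[nH]c12`) gives 29000 nM and compound 3 (`CN(C)C(=O)c1cc(-c2cnc(NCc3c(F)ccc4c3CCO4)c3cn[nH]c(=O)c23)n(C)n1`) gives 3000 nM, both lower than compound 1 by more than the scatter. Among the compounds with values here, no measured pair differs in one place only. Compound 4 (`O=C(Nc1cnc(NCc2c(F)ccc3c2CCO3)n2cnnc12)c1cccnc1`) has ((pyridin-3-yl)carbonyl)amino in place of 4-methyl-2-oxopyrrolidin-1-yl on an aromatic carbon. With no direct comparison available, the only ground for direction is that compound 1 at 130000 nM lies at the top of the series. A fall beyond the scatter is therefore expected in this assay and estimated as an 8.7-fold lower number from compound 1 to compound 4 (0.94 log units; beyond the scatter) overall. For compound 4 the estimated value is 15000 nM with an expected range from 3000 nM to 60000 nM in this measurement.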

Compound 4, solubility: 12000 nM
Beside the measured number, compound 4's estimate is 1.3-fold (0.10 log units) above it; the range from low to high includes it.
By their numbers in this assay, from the lowest: compound 3; then compound 4; then compound 2; then compound 1.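

In this assay, this aromatic carbon of the shared core is sensitive to its substituent: ((pyridin-3-yl)carbonyl)amino in place of 4-methyl-2-oxopyrrolidin-1-yl gives an 11-fold lower number from compound 1 to compound 4 (1.03 log units; beyond the scatter), a large step and the only one read at a single place. The swap exchanges a five-membered non-aromatic ring for a six-membered aromatic ring, adds a hydrogen-bond donor and removes the stereocentre, so several features change together. Nothing measured bears on the cause of this step.

Which of these features carries the step remains open. So does the reading in this assay with a simple amine or a carboxylic acid on this aromatic carbon.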